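Ester variation on the shared core: benzyl to isopropyl

The source may hold more compounds than are shown below. What is called first, only, known or untested is meant among the compounds shown, and "the series" means these compounds.

Among the measured compounds shown here, compound 1 `CC/C=C\C[C@H]1C(=O)C=C[C@H]1CC(=O)OCc1ccccc1` carries a benzyl ester on the shared core; in a functional assay on RAW264.7 cells (Mus musculus) for inhibition, read by ELISA, with a stated time of 24 h (on this read-out lower numbers stand for an effect already at smaller amounts and higher numbers for an effect only at larger amounts of compound), compound 1 gives 20000 nM, the lowest of the two numbers known so far. For the measured compounds named here, compound 2 `CC/C=C\C[C@H]1C(=O)C=C[C@H]1CC(=O)OCCOCCOCCO` gives 42000 nM in this assay; the step of a 2.1-fold higher number from compound 1 to compound 2 (0.32 log units; beyond the scatter) is the only measured change at this ester position, and it is modest. Compound 3 `CC/C=C\C[C@H]1C(=O)C=C[C@H]1CC(=O)OC(C)C` differs from compound 1 by isopropyl in place of benzyl on an oxygen next to a carbonyl group. Going by the values given here, with a single modest step as the sole guide and no measured isopropyl ester, a step of similar or smaller size is expected for compound 3, without a clear direction. For compound 3 a value of 25000 nM is expected, within 10000 nM to 60000 nM, which means an estimated step of a 1.3-fold higher number from compound 1 to compound 3 (0.10 log units; within the scatter).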

Compound 3, half-maximal effective concentration: 20000 nM
The estimate for compound 3 lay 1.3-fold (0.10 log units) above the measured number; low and high end bracket the measured number.
By their numbers in this assay, from the lowest: compounds 1 and 3 (each within the scatter of the next); then compound 2.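

In this assay, isopropyl in place of benzyl on an oxygen next to a carbonyl group gives no change at the digits printed from compound 1 to compound 3 (within the scatter), so the value of compound 1 does not depend on the aromatic ring at this position. The ester position therefore accepts a much smaller carbon-only group with no visible loss, whereas only the chain of compound 2 has so far given a step beyond the scatter. No available evidence bears on the reason for this result.

Still open, from the compounds shown here alone, is how a free carboxylic acid, an amide or a longer alkyl chain at this position would read. Also open, going by these compounds, is whether any ester group can give a number clearly lower than those of compound 1 and compound 3.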